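Adding a second methoxy to the benzyl ether

The source may report more compounds than this note shows. Statements on the series, on what has been measured and on what is new or still open speak of the compounds shown alone.

Compound 1 `CCOc1cc(N)c(Cl)cc1C(=O)CCCCN1CCCCC1`: < 7
Compound 2 `COc1ccc(COc2cc(N)c(Cl)cc2C(=O)CCCCN2CCCCC2)cc1`: 8.4

In a functional assay for antagonist activity at 5-hydroxytryptamine receptor 4 (Rattus norvegicus) (on this read-out lower numbers stand for lower potency and higher numbers for higher potency (the scale is a negative logarithm)), compound 1 reaches only a limit, < 7 (the limit of < 7 in this assay, at which 1 of the 2 values shown sits). Among the compounds with values here, compound 2 gives 8.4 and so holds the only number in this set. The step of a number at least 1.40 log units higher from compound 1 to compound 2 (beyond the scatter) is large. Compound 3 `COc1ccc(COc2cc(N)c(Cl)cc2C(=O)CCCCN2CCCCC2)cc1OC` differs from compound 2 by methoxy in place of hydrogen on an aromatic carbon. Within the data shown here, no measured step concerns this kind of change; the single measured step altered a different group. Compound 3 is therefore expected to change by a number 0.10 log units lower from compound 2 to compound 3 (within the scatter), not beyond the scatter. Compound 3 is estimated at 8.3, between 7.6 and 9.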

Compound 3, negative logarithm of the antagonist equilibrium constant: 8.5
Compound 3: the middle estimate sits 0.20 log units below what was measured; low and high end bracket the measured number.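

In this assay, the change from 4-methoxyphenyl to 3,4-dimethoxyphenyl, with the new methoxy ortho to a methoxy group, gives a number 0.10 log units higher from compound 2 to compound 3 (within the scatter), so this aromatic carbon accepts a methoxy with no shift beyond the scatter. The large step from the core of compound 1 also holds with the second methoxy in place, as a number at least 1.50 log units higher from compound 1 to compound 3 (beyond the scatter). The figure for compound 1 remains a limit: the limit of < 7 in this assay, at which 1 of the 3 values shown sits.

On these data alone, whether an amine or a carboxylic acid on this aromatic carbon would read the same stays open. So does the effect of a longer chain in place of the new methoxy.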